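The source may report more compounds than this note shows. Statements on the series, on what has been measured and on what is new or still open speak of the compounds shown alone.

Of the compounds shown here, two sharing one core have so far been tested in an assay for inhibition of Intestinal-type alkaline phosphatase (Homo sapiens), read by spectrophotometry, with stated times of 10 min and 20 min; a lower number here means a stronger inhibitor, a higher number a weaker inhibitor. Compound 1 `COc1ccc(/C=C2\NS(=O)(=O)c3ccccc3C2=O)cc1` gives 1530 nM. Compound 2 `O=C1/C(=C/c2ccccc2Br)NS(=O)(=O)c2ccccc21` gives 7430 nM, the higher of the two numbers, and its gap to compound 1 lies beyond the usual scatter of repeated measurements, so compound 2 is the weaker inhibitor of the pair.

Compound 3 `O=C1/C(=C/c2ccc(F)cc2)NS(=O)(=O)c2ccccc21` has not yet been measured in this assay . It differs from compound 2 in a single place: 4-fluorophenyl in place of 2-bromophenyl on a double-bonded chain carbon bound to a double-bonded ring carbon. Among the measured compounds shown here, no step between two measured compounds matches this change, so nothing more than the two values above can guide the expectation. Since compound 1 gives the lower number with a different group at the same place, a modest move toward a lower number is expected for compound 3, close to the edge of the scatter. The estimate for compound 3 in this assay is 3500 nM, with a range from 1200 nM to 10000 nM. That estimate corresponds to an expected step of a 2.1-fold lower number from compound 2 to compound 3 (0.33 log units; beyond the scatter).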

Compound 3, half-maximal inhibitory concentration: 3060 nM
The estimate for compound 3 lay 1.1-fold (0.06 log units) above the measured number; low and high end bracket the measured number.
By their numbers in this assay, from the lowest: compounds 1 and 3 (each within the scatter of the next); then compound 2.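

In this assay, the group on the double-bonded chain carbon clearly matters: 4-fluorophenyl in place of 2-bromophenyl gives a 2.4-fold lower number from compound 2 to compound 3 (0.39 log units; beyond the scatter). Fluoro in place of methoxy on an aromatic carbon gives a 2.0-fold higher number from compound 1 to compound 3 (0.30 log units; within the scatter), so compound 1 and compound 3 cannot be told apart in this test. Among the compounds shown here, nothing measured so far explains either step.

The step from 2-bromophenyl to 4-fluorophenyl changes both the halogen and where it sits on the ring, so the compounds shown cannot say which of the two matters; 2-fluorophenyl and 4-bromophenyl would separate them. Also open, from the compounds shown here alone, is how an aromatic ring carrying an amine or a carboxylic acid would behave at this place.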